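The source may hold more compounds than are shown below. What is called first, only, known or untested is meant among the compounds shown, and "the series" means these compounds.

Measured so far:
compound 1, `COc1ccc(-c2cc(-c3ccc(S(=O)(=O)NC4CC4)cc3)cnc2N)cn1`: in a physicochemical assay for solubility, read by nephelometry, measured as kinetic solubility, at pH 2 (on this read-out lower numbers stand for lower solubility and higher numbers for higher solubility), compound 1 gives > 100 ug/mL, which is a limit of the assay.
compound 2, `COc1ccc(-c2cc(-c3ccc(C(F)(F)F)cc3)cnc2N)cn1`: in this assay compound 2 gives > 100 ug/mL, also a limit of the assay.

For the measured compounds named here, compound 2 therefore stands at the upper limit of this assay, with no number behind it, and the one other value shown is a limit as well. Going by the values given here, the single measured step, a step that the two limits leave unreadable from compound 1 to compound 2, cannot be sized because both of its ends sit at the limit of > 100 ug/mL in this assay, at which 2 of the 2 values shown sit. Compound 3 is `COc1ccc(-c2cc(-c3ccc(C(=O)N(C)C)cc3)cnc2N)cn1` and differs from compound 2 by dimethylcarbamoyl in place of trifluoromethyl on an aromatic carbon. Among the compounds with values here, no measured step bears on this change in this assay. As both values shown sit at the limit, compound 3 is expected to remain at that limit too, and the expected step that the limit leaves unreadable from compound 2 to compound 3 is none readable beyond the scatter. The estimate for compound 3 is 150 ug/mL, with a range from 70 ug/mL to 400 ug/mL.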

Compound 3, solubility: > 100 ug/mL
Compound 3: only a limit was reported (the forecaster's own chance of this, stated with the estimate: 75%); the middle value lies beyond the limit too.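

In this assay compound 3 gives > 100 ug/mL, a limit of the assay. No step among compound 1, compound 2 and compound 3 can be read: the limit of > 100 ug/mL in this assay, at which 3 of the 3 values shown sit.

The compounds shown leave open how far apart these three compounds lie, as none has a number behind its limit.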